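Anilide acyl group: benzoyl to acetyl in the series

The source may hold more compounds than are shown below. What is called first, only, known or untested is meant among the compounds shown, and "the series" means these compounds.

Compound 3 `COc1cc(/C=C/C(=O)c2cccc(NC(=O)c3ccccc3)c2)ccc1O` stands second highest of the three numbers in a functional assay on HUVEC cells (Homo sapiens) for inhibition, tested at 10 ug/mL (a higher number here means a stronger effect of the compound at the concentration tested, a lower number a weaker effect), where compound 3 gives 69%. Compound 1 `COc1cc(/C=C/C(=O)c2cccc(NC(=O)c3cccs3)c2)ccc1O` gives 90% and compound 2 `COc1cc(/C=C/C(=O)c2cccc(NC(=O)c3ccc(Cl)c(Cl)c3)c2)ccc1O` gives 45%; the steps of a number 21 percentage points lower from compound 1 to compound 3 (beyond the scatter) and a number 24 percentage points higher from compound 2 to compound 3 (beyond the scatter) are both modest, while a number 45 percentage points lower from compound 1 to compound 2 (beyond the scatter) is large. Compound 4 `COc1cc(/C=C/C(=O)c2cccc(NC(C)=O)c2)ccc1O` differs from compound 3 by methyl in place of phenyl on a carbonyl carbon. Going by the values given here, no measured step trades an aromatic ring for a methyl on this carbonyl carbon; the three steps only exchange one ring for another, and each of those moved the read-out beyond the scatter. A step beyond the scatter is therefore plausible here too, and a modest fall is expected as the working guess, a number 14 percentage points lower from compound 3 to compound 4 (beyond the scatter). Compound 4 is expected to give about 55%, within 30% to 80%.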

Compound 4, a percentage reported as inhibition, at one concentration (the size of the read-out at that concentration, not a potency): 32%
The estimate for compound 4 lay 23 percentage points above the measured number; low and high end bracket the measured number.
By their numbers in this assay, from the lowest: compound 4; then compound 2; then compound 3; then compound 1.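

In this assay methyl on this carbonyl carbon stands below every ring shown, with a number 37 percentage points lower from compound 3 to compound 4 (beyond the scatter) and a number 13 percentage points lower from compound 2 to compound 4 (beyond the scatter) and a number 58 percentage points lower from compound 1 to compound 4 (beyond the scatter) as the three steps. Across these four compounds, a ring on this carbonyl carbon goes with the higher read-out, even the 3,4-dichlorophenyl of compound 2, and no compound goes against this. Nothing at hand gives a cause for these steps.

On these data alone, whether an aromatic ring is needed here or any larger group serves stays open: cyclohexyl or a longer chain such as butyl on this carbonyl carbon would separate the two.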